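A few compounds are considered here, and "the series" means these few. Any claim that something is new, unique, unknown or untested is made for them only; others in the source may bear on it.

Working notes on the series: in an ADME assay on L02 cells (Homo sapiens) for cytotoxicity, read by MTT assay, with a stated time of 24 h (on this read-out higher numbers stand for weaker inhibition and lower numbers for stronger inhibition), compound 1 `Cc1ccc(S(=O)(=O)N2C/C(=C\c3ccncc3)C(=O)/C(=C/c3ccccc3F)C2)cc1` reads > 20000 nM, which is a limit of the assay and not a number. Within the data shown here, compound 2 `O=C1/C(=C/c2ccncc2)CN(S(=O)(=O)c2ccc(Cl)cc2)C/C1=C\c1ccccc1F` gives 15000 nM, the only actual number so far, so its standing can be judged only against compound 1. The next change leads to compound 3 `N#Cc1ccc(S(=O)(=O)N2C/C(=C\c3ccncc3)C(=O)/C(=C/c3ccccc3F)C2)cc1`, with cyano in place of chloro on an aromatic carbon, para to a large group: cyano in place of chloro on an aromatic carbon. Among the measured compounds shown here, one measured step bears on this, made at the same aromatic carbon: an at least 1.3-fold lower number from compound 1 to compound 2 (0.12 log units; that floor lies within the scatter). That step gives no sign of a change beyond the scatter in this assay, so none is expected here, and no direction can be called with confidence. The expected step is a 1.2-fold higher number from compound 2 to compound 3 (0.08 log units; within the scatter). Compound 3 may also end up at the limit of > 20000 nM in this assay, at which 1 of the 2 values shown sits. For compound 3 the estimated value is 18000 nM, with an expected range from 9000 nM to 35000 nM.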

Compound 3, half-maximal inhibitory concentration: > 20000 nM
Compound 3: only a limit was reported (the forecaster's own chance of this, stated with the estimate: 45%); at least 1.1-fold (0.04 log units) between middle value and limit.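

In this assay, going from 4-chlorophenyl to 4-cyanophenyl at this aromatic carbon gives an at least 1.3-fold higher number from compound 2 to compound 3 (0.12 log units; that floor lies within the scatter), so neither of the steps readable at this position is shown to exceed the scatter. Among these compounds, the series now has three groups at this carbon, and methyl and cyano both end at a limit of the assay, leaving chloro in compound 2 as the only one with an actual number: the limit of > 20000 nM in this assay, at which 2 of the 3 values shown sit. The step between compound 1 and compound 3 cannot be read, as both values are limits.

From the compounds shown here alone, how far compound 1 and compound 3 lie past that limit stays open, so methyl and cyano cannot be ranked. Also open, going by these compounds, is whether an amine or a carboxylic acid at this carbon would bring a number in this assay clearly beyond the scatter from that of compound 2.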